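Swapping the anilino aryl in a thioacetamide series

This account rests on a few compounds, and the source may have more. Where it says the series, first, only, none or still open, it means among the compounds named here.

Of the compounds shown here, three of a shared core have been measured in a functional assay on NCI-H1975 cells (Homo sapiens) for inhibition, read by MTT assay, with a stated time of 72 h; on this read-out lower numbers stand for stronger inhibition and higher numbers for weaker inhibition. Compound 1 `O=C(CSc1nc(Nc2ccccc2)c2ccccc2n1)Nc1ccc(F)cc1` gives 16500 nM in this assay. Among the compounds with values here, compound 2 `CCc1ccc(NC(=O)CSc2nc(Nc3ccccc3)c3ccccc3n2)cc1` gives 9910 nM in this assay, and the only single-point step measured so far, a 1.7-fold lower number from compound 1 to compound 2 (0.22 log units; within the scatter), does not rise above the scatter. Compound 3 `C=CC(=O)Nc1cccc(NC(=O)CSc2nc(Nc3ccccc3C)c3ccccc3n2)c1` gives 9920 nM in this assay; its number lies within the scatter of compound 2 and also within the scatter of compound 1, so the three compounds sit together and none can be told apart from the others.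

Compound 4 `C=CC(=O)Nc1cccc(NC(=O)CSc2nc(Nc3ccc(F)c(Cl)c3)c3ccccc3n2)c1` is not yet measured. It differs from compound 3 in one place: 3-chloro-4-fluorophenyl in place of 2-methylphenyl on a nitrogen on an aromatic ring. Within the data shown here, no measured step touches this nitrogen on an aromatic ring; the single step that exists concerns the fluoro and ethyl on the other aryl amide and was itself within the scatter. There is therefore nothing to support a change beyond the scatter in this assay, in either direction. Compound 4 is estimated at 7000 nM, with a range from 2500 nM to 20000 nM. The expected step of a 1.4-fold lower number from compound 3 to compound 4 (0.15 log units; within the scatter) is small and carries the width of the scatter as its main uncertainty.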

Compound 4, half-maximal inhibitory concentration: > 50000 nM
Compound 4: only a limit was reported; the forecaster's own chance of this, stated with the estimate: 5%; middle value at least 7.1-fold (0.85 log units) from the limit.
By their numbers in this assay, from the lowest: compounds 2, 3 and 1 (each within the scatter of the next). At a limit, above all of these: compound 4.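

Within the data shown here, the aryl on the nitrogen on an aromatic ring, which no earlier step had touched, proves to be a place where this assay responds to a single change: 3-chloro-4-fluorophenyl in place of 2-methylphenyl gives an at least 5.0-fold higher number from compound 3 to compound 4 (0.70 log units; beyond the scatter), the first step in this set to pass beyond the scatter. Compounds 1, 2 and 3 could not be told apart, so this swap is the first single change shown to separate two compounds of the shared core. The value of compound 4 is a limit and not a number, so the step has a lower bound but no measured size: the limit of > 50000 nM in this assay, at which 1 of the 4 values shown sits.

The swap removes the methyl and brings in chloro and fluoro together, so the compounds shown cannot say which of these parts accounts for the step, and they give no cause for it. Compounds that keep the rest of compound 3 but carry an unsubstituted phenyl, a phenyl with only the chloro or only the fluoro, or a methoxy-bearing phenyl on this nitrogen would be needed to separate these parts.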